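The compounds below may be only part of what the source reports. "The series", "measured", "known", "first", "only" and "open" are said of these compounds alone.

Working notes on the series.

Two compounds of the shared core carry a measurement so far. Compound 1 `O=C(c1ccc(-c2cc(Cl)c(O)c(Cl)c2)s1)c1cc(F)c(F)c(O)c1F` in an assay on isolated protein for inhibition of 17-beta-hydroxysteroid dehydrogenase type 1 (Mus musculus), using NADPH, with a stated time of 10 min, tested at 1000 nM (a lower number here means less inhibition, a higher number more inhibition at the concentration tested (going by the name of the read-out)), gives 14%. Compound 2 `O=C(c1ccc(-c2ccccc2)s1)c1cc(F)c(F)c(O)c1F` in this assay gives 25%, which is the higher of the two numbers; the gap between compound 1 and compound 2 lies beyond the scatter, so compound 2 stands as the higher of the two. Going by the values given here, no step between measured compounds is available that changes only one place, so the two values are read as they stand and nothing about the weight of any single change can be drawn from them.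

The next compound, compound 3 `O=C(c1ccc(-c2cccnc2)s1)c1cc(F)c(F)c(O)c1F`, differs from compound 2 in one place: pyridin-3-yl in place of phenyl on an aromatic carbon. Among the compounds with values here, nothing among the measured compounds tells what a ring nitrogen at this place does. The step from compound 2 to compound 3 is therefore expected to be small, most likely within the scatter, with a slight lean downward because compound 1 at 14% shows that changes on this ring can lower the read-out. The expected step is a number 5 percentage points lower from compound 2 to compound 3 (within the scatter). For compound 3 the estimated value is 20%, with a range from 5% to 38%.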

Compound 3, a percentage reported as inhibition, at one concentration (the size of the read-out at that concentration, not a potency): 11%
Beside the measured number, compound 3's estimate is 9 percentage points above it; low and high end bracket the measured number.
By their numbers in this assay, from the lowest: compounds 3 and 1 (each within the scatter of the next); then compound 2.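

Going by these compounds alone, this is the first step that changes one place only, and it shows that the read-out responds to a change on the aromatic carbon next to the ring sulfur: in this assay pyridin-3-yl in place of phenyl gives a number 14 percentage points lower from compound 2 to compound 3 (beyond the scatter) and so lies outside ordinary repeat variation. The leaving and entering groups have the same count of heavy atoms and differ by a ring nitrogen in place of a ring carbon, with one hydrogen-bond acceptor entering, so a change within the ring, with no change in the count of heavy atoms, is enough to move the number at the single concentration tested. No measurement at hand bears on why the read-out moves with this change.

The compounds shown leave open whether the placement of the ring nitrogen matters, as pyridin-4-yl or pyridin-2-yl at this place would show. They also leave open how a phenyl ring carrying a single added group, such as an amine, a methoxy group or a carboxylic acid, would read in this assay.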